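The compounds below may be only part of what the source reports. "The series", "measured", "known", "first", "only" and "open" are said of these compounds alone.

Compound 2 `CN1CCN(CCn2c(=O)oc3cccnc32)CC1` is the smaller member of the pair that has been measured. In a functional assay on the whole organism with Mus musculus as the target (a lower number here means that less compound is needed, a higher number that more compound is needed for the effect), compound 2 gives > 25 mg/kg, which is a limit of the measurement and not a number. Compound 1 `O=c1oc2cccnc2n1CCN1CCN(c2ccc(F)cc2)CC1` carries the 4-fluorophenyl instead, and in this assay compound 1 gives 41.3 mg/kg. Within the data shown here, the only measured step, a step that the limit leaves unreadable from compound 1 to compound 2, cannot be read because of the limit of > 25 mg/kg in this assay, at which 1 of the 2 values shown sits. Compound 3 `COc1ccccc1N1CCN(CCn2c(=O)oc3cccnc32)CC1` differs from compound 2 as follows: 2-methoxyphenyl in place of methyl on an amine nitrogen in a ring. Among the measured compounds shown here, the one measured step bearing on this change is the unreadable one from compound 1 to compound 2, so no direction can be taken from it; the expectation therefore rests on compound 1 alone, whose value 41.3 mg/kg shows what an aryl group in this position gives. Compound 3 is thus expected at 40 mg/kg, within a range of 15 mg/kg to 110 mg/kg, which amounts to an expected step that the limit leaves unreadable from compound 2 to compound 3.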

Compound 3, dose for half-maximal effect: > 50 mg/kg
Compound 3 gave a limit, no number; the forecaster's own chance of this, stated with the estimate: 35%; middle value at least 1.2-fold (0.09 log units) from the limit.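

In this assay, among these compounds, 2-methoxyphenyl in place of 4-fluorophenyl on the amine nitrogen in the ring gives an at least 1.2-fold higher number from compound 1 to compound 3 (0.08 log units; that floor lies within the scatter), the only readable step at this position, and it is a floor that fixes no size and sets no order between the two aryl groups. For compound 3 the entry > 50 mg/kg is a limit and not a number. The steps that involve compound 2 cannot be read, so the two aryl groups cannot be set against methyl at this position.

Going by these compounds, how far compound 3 actually lies from compound 1 stays open, as does whether any aryl group here differs from methyl at all. Also open, on these data alone, is what an unsubstituted phenyl or a benzyl on the same amine nitrogen would give in this assay.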